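This account rests on a few compounds, and the source may have more. Where it says the series, first, only, none or still open, it means among the compounds named here.

In a functional assay on HCT-116 cells (Homo sapiens) for inhibition, read by MTT assay, with a stated time of 48 h (a higher number here means a weaker inhibitor, a lower number a stronger inhibitor), compound 1 (`COc1ccc(N(C)c2nc(C)nc3ccccc23)cc1OCCC[Se]C#N`) gives 852 nM, compound 2 (`COc1ccc(N(C)c2nc(C)nc3ccccc23)cc1C(=O)NCC[Se]C#N`) gives 313 nM, and compound 3 (`COc1ccc(N(C)c2nc(C)nc3ccccc23)cc1OCC[Se]C#N`) gives 18 nM, the lowest number of the three. Compound 4 (`COc1ccc(N(C)c2nc(C)nc3ccccc23)cc1OCCCCC[Se]C#N`) carries a longer chain than compound 3: a group of 6 heavy atoms (4 carbon, 1 nitrogen, 1 selenium; no ring) in place of a group of 3 heavy atoms (1 carbon, 1 nitrogen, 1 selenium; no ring), on a saturated chain carbon, two bonds along the chain from an oxygen on an aromatic ring. The closest evidence is a 47-fold lower number from compound 1 to compound 3 (1.68 log units; beyond the scatter), a large step that goes with a shorter chain. Less direct is a 17-fold lower number from compound 2 to compound 3 (1.24 log units; beyond the scatter), also large, which involves an amide-containing chain. No chain as long as that of compound 4 has been measured, so the range stays wide. A large step to a higher number is expected in this assay, estimated as a 33-fold higher number from compound 3 to compound 4 (1.52 log units; beyond the scatter). Compound 4 is estimated at 600 nM, with an expected range of 110 nM to 3000 nM.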

Compound 4, half-maximal inhibitory concentration: 256 nM
Compound 4: middle estimate off by 2.3-fold (0.37 log units), on the high side; low and high end bracket the measured number.
By their numbers in this assay, from the lowest: compound 3; then compounds 4 and 2 (each within the scatter of the next); then compound 1.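

In this assay, the shortest chain still gives the lowest number, with a 14-fold higher number from compound 3 to compound 4 (1.15 log units; beyond the scatter), but the numbers do not rise steadily with chain length: there is a 3.3-fold lower number from compound 1 to compound 4 (0.52 log units; beyond the scatter), although compound 4 carries the longer chain. Compound 1 therefore goes against any simple rise with length. The amide-containing chain and the longest chain give numbers that cannot be separated, with a 1.2-fold lower number from compound 2 to compound 4 (0.09 log units; within the scatter). No available evidence accounts for this pattern. As far as these compounds go, whether a chain longer than that of compound 4 continues this pattern remains open, as does the effect of a thiocyanate in place of the selenium-bearing end group.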